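The source may hold more compounds than are shown below. What is called first, only, known or untested is meant among the compounds shown, and "the series" means these compounds.

Measured so far in a functional assay on Jurkat cells (Homo sapiens); a lower number here means a stronger inhibitor, a higher number a weaker inhibitor:
Compound 1, `CC(C)[C@H](NC(=O)COc1cccc2ccccc12)C(=O)N[C@@H](CC(=O)O)C(=O)COc1ccc(C(N)=O)cc1`: > 100000 nM
Compound 2, `CC(C)[C@H](NC(=O)COc1cccc2ccccc12)C(=O)N[C@@H](CC(=O)O)C(=O)COc1ccc(Oc2ccccc2)cc1`: 12700 nM

Compound 1 stands at the weak end of the two numbers shown. In this assay compound 1 reaches only a limit of the assay and not a number, > 100000 nM, as the limit of > 100000 nM in this assay, at which 1 of the 2 values shown sits, records. Compound 2 gives 12700 nM in this assay. Among the compounds with values here, the single measured step, an at least 7.8-fold lower number from compound 1 to compound 2 (0.89 log units; beyond the scatter), is the only one that bears on the change considered here, and it is at least modest in size.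

Compound 3, `CC(C)[C@H](NC(=O)COc1cccc2ccccc12)C(=O)N[C@@H](CC(=O)O)C(=O)COc1c(F)ccc(F)c1F`, differs from compound 1 in one place: 2,3,6-trifluorophenyl in place of 4-carbamoylphenyl on an oxygen on a saturated carbon. As in the step to compound 2, the group that leaves is the 4-carbamoylphenyl and the group that enters carries no carbamoyl, so a step in the same direction is expected, toward a lower number beyond the scatter, though its true size is uncertain since compound 1 has only a limit. The expected step is an at least 20-fold lower number from compound 1 to compound 3 (1.30 log units; beyond the scatter). Compound 3 is therefore estimated at 5000 nM, with a range from 500 nM to 50000 nM.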

Compound 3, half-maximal inhibitory concentration: 1200 nM
Estimate against measurement, compound 3: 4.2-fold (0.62 log units) above, within the range that was stated.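

The step of an at least 83-fold lower number from compound 1 to compound 3 (1.92 log units; beyond the scatter) shows that this place, on an oxygen on a saturated carbon, takes a 2,3,6-trifluorophenyl group in this assay, and that a lower number there does not depend on the phenoxy group of compound 2. The group that enters has the same count of heavy atoms as the 4-carbamoylphenyl that leaves, but it has no hydrogen-bond donor or acceptor, so the change is one of substituents on a single six-membered aromatic ring and not of added size. Both replacements of the 4-carbamoylphenyl now give measured values, with compound 2 at 12700 nM and compound 3 at 1200 nM, so the lower number is seen with two quite different groups.

The compounds shown leave open how an unsubstituted phenyl, a pyridine ring or a cyclohexyl group would read at this place, and how many of the three fluorines are needed. The true size of the step also stays unknown because compound 1 has a limit of the assay and not a number: the limit of > 100000 nM in this assay, at which 1 of the 3 values shown sits.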